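A few compounds are considered here, and "the series" means these few. Any claim that something is new, unique, unknown or untested is made for them only; others in the source may bear on it.

Of the compounds shown here, three sharing one core have been tested in a functional assay on U2OS cells (Homo sapiens) for cytotoxicity, read by MTT assay, with a stated time of 48 h; on this read-out higher numbers stand for weaker inhibition and lower numbers for stronger inhibition. Compound 1, `COc1ccccc1Nc1nc(-c2cccc(F)c2)nc2ccc(F)cc12`, gives in this assay only a limit, > 50000 nM. Compound 2, `Fc1ccc(Nc2nc(-c3cccc(F)c3)nc3ccc(F)cc23)cc1`, likewise gives in this assay only a limit, > 50000 nM. Compound 3, `Fc1cccc(-c2nc(Nc3cccc(Cl)c3)c3cc(F)ccc3n2)c1`, also gives in this assay only a limit, > 50000 nM. So compound 2 stands exactly where every measured compound stands: at the limit, with no number of its own. The steps between these compounds cannot be sized: a step that the two limits leave unreadable from compound 1 to compound 2, a step that the two limits leave unreadable from compound 1 to compound 3 and a step that the two limits leave unreadable from compound 2 to compound 3 are each left unreadable because of the limit of > 50000 nM in this assay, at which 3 of the 3 values shown sit.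

Compound 4, `Oc1cccc(Nc2nc(-c3cccc(F)c3)nc3ccc(F)cc23)c1`, is still to be measured in this assay. It differs from compound 2 in one place: 3-hydroxyphenyl in place of 4-fluorophenyl on a nitrogen on an aromatic ring. The two measured steps that touch compound 2, from compound 1 and to compound 3, each exchange one ring in this same place and each remain unreadable, so they give neither a size nor a direction to carry forward. What they do show is that three different rings in this place all leave the compounds at the limit. Compound 4 is therefore expected to return the limit as well, with an estimate of 50000 nM in this assay and a range from 20000 nM to 100000 nM. The expected step, a number no higher from compound 2 to compound 4 (the limit leaves the size open), is accordingly nothing beyond the scatter.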

Compound 4, half-maximal inhibitory concentration: 33300 nM
For compound 4 the middle estimate is 1.5-fold (0.18 log units) above the measured one, within the range that was stated.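

Among the compounds shown here, until now every ring tried on this nitrogen had left the compound at a limit, and 3-hydroxyphenyl is the first to give a number of its own in this assay, so this position can at least reach the measurable range. Each step to compound 4 is only a floor, an at least 1.5-fold lower number from compound 2 to compound 4 (0.17 log units; that floor lies within the scatter), an at least 1.5-fold lower number from compound 3 to compound 4 (0.17 log units; that floor lies within the scatter) and an at least 1.5-fold lower number from compound 1 to compound 4 (0.17 log units; that floor lies within the scatter), so the result alone does not establish a real gain over the other rings. The true size of all three steps stays unreadable because the other compounds have no number of their own: the limit of > 50000 nM in this assay, at which 3 of the 4 values shown sit.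

The compounds shown leave open whether the measured number belongs to the hydroxy group itself or to where it sits on the ring, a question that a 4-hydroxyphenyl in the same place would help to settle. They also leave open how a 3-aminophenyl or a 3-carboxyphenyl ring would read here, and whether any ring on this nitrogen can bring the number well clear of the limit.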